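Extending a methoxy to butoxy on the shared core

A few compounds are considered here, and "the series" means these few. Any claim that something is new, unique, unknown or untested is made for them only; others in the source may bear on it.

Measured compounds:
- compound 1 `COc1ccc([C@@H]2CC(=O)c3cc(CC=C(C)C)c(OC)cc3O2)cc1` gives 58%
- compound 2 `COc1ccc([C@@H]2C/C(=N/OCc3cn(-c4ccc(C(=O)c5ccccc5)cc4)nn3)c3cc(CC=C(C)C)c(OC)cc3O2)cc1` gives 40%

Among the compounds with values here, in a functional assay on PC-3 cells (Homo sapiens) for inhibition, read by sulforhodamine B assay, with a stated time of 48 h, tested at 50 uM (a higher number here means more inhibition of growth at the concentration tested, a lower number less inhibition of growth), compound 1 holds the highest of the two numbers so far, with compound 1 giving 58% against compound 2 giving 40%, a gap that falls beyond the scatter. Compound 3 `CCCCOc1ccc([C@@H]2CC(=O)c3cc(CC=C(C)C)c(OC)cc3O2)cc1` has not yet been measured in this assay. It differs from compound 1 in one place: propyl in place of hydrogen on a saturated chain carbon bound to an oxygen on an aromatic ring. Put another way, the methoxy on the aromatic ring becomes a butoxy. Within the data shown here, no step between two measured compounds mirrors this change, so there is no direct guide to its size. The account expects no step beyond the scatter in this assay, with the chance of a slight rise, since the rest of the core is kept intact. For compound 3 the estimate is 60%, within 40% to 78%, a step expected to be a number 2 percentage points higher from compound 1 to compound 3 (within the scatter).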

Compound 3, percent growth inhibition at one concentration: 48%
Estimate against measurement, compound 3: 12 percentage points above; the measured number falls inside the stated range.
By their numbers in this assay, from the lowest: compounds 2, 3 and 1 (each within the scatter of the next, the first and the last beyond it).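

In this assay, the first single change read at this position gives a number 10 percentage points lower from compound 1 to compound 3 (within the scatter), so the methoxy on the aromatic ring can become a butoxy without a step beyond the usual scatter. Within the data shown here, no earlier step between measured compounds touched this place, and this one shows that propyl in place of hydrogen on this saturated chain carbon bound to an oxygen leaves growth inhibition on the shared core indistinguishable from that of compound 1. No measured evidence bears on this result.

The compounds shown leave open how an ethoxy, a hexyloxy or a butoxy chain ending in an amine would read at this place. They also leave open whether a butoxy in place of the methoxy would give a similar step in the structure of compound 2.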